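Removing the Methoxy Group from Compound 3

This account rests on a few compounds, and the source may have more. Where it says the series, first, only, none or still open, it means among the compounds named here.

Measured compounds:
compound 1, `Fc1ccc(Nc2cc(Nc3ccc(Oc4ccncc4-c4cccnc4)c(F)c3)ncn2)cc1F`: 7630 nM
compound 2, `Fc1ccc(Nc2cc(Nc3ccc(Oc4ccncc4-c4cccnc4)c(F)c3)ncn2)cc1`: 710 nM
compound 3, `COc1ccc(-n2nc(C(=O)Nc3ccc(Oc4ccncc4-c4cccnc4)c(F)c3)c3ccccc3c2=O)cc1`: 6800 nM

All three compounds were tested in a functional assay on A549 cells (Homo sapiens) for cytotoxicity, read by MTT assay, with a stated time of 72 h; a lower number here means a stronger inhibitor, a higher number a weaker inhibitor. Compound 3 stands second highest of the three numbers: its value lies close to that of compound 1, within the usual scatter, while compound 2 gives a number far lower than compound 3, beyond the scatter.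

Compound 4, `O=C(Nc1ccc(Oc2ccncc2-c2cccnc2)c(F)c1)c1nn(-c2ccccc2)c(=O)c2ccccc12`, is the next compound to be measured. It differs from compound 3 in one place: hydrogen in place of methoxy on an aromatic carbon. Among the measured compounds shown here, the only measured step in this set, an 11-fold lower number from compound 1 to compound 2 (1.03 log units; beyond the scatter), concerns a different group on a different ring and so says nothing about a methoxy group. For the measured compounds named here, no measured step bears on the change at hand. With nothing to point either way, the expected change is no change at the digits printed from compound 3 to compound 4 (within the scatter), that is, nothing beyond the scatter. Compound 4 is therefore estimated at 6800 nM, with a plausible range from 2300 nM to 20000 nM.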

Compound 4, half-maximal inhibitory concentration: 7900 nM
The estimate for compound 4 lay 1.2-fold (0.07 log units) below the measured number; the measured number falls inside the stated range.
By their numbers in this assay, from the lowest: compound 2; then compounds 3, 1 and 4 (each within the scatter of the next).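

In this assay, going from the 4-methoxyphenyl to the phenyl gives a 1.2-fold higher number from compound 3 to compound 4 (0.07 log units; within the scatter) and so leaves the number inside the usual scatter. Among the compounds shown here, at this place, on the carbon-only aromatic ring and para to a large group, the methoxy group can therefore be replaced by hydrogen without any readable effect on the number, which the earlier compounds could not show, as their single step concerned a fluoro group on a different ring. Nothing measured here offers an explanation for this result.

As far as these compounds go, what remains open is whether a larger or differently built group at the same place, such as an amine, a carboxylic acid or a longer chain like butoxy, would also leave the number within the scatter. A single pair also cannot show whether the same replacement would read alike on a different core.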